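The source may hold more compounds than are shown below. What is called first, only, known or untested is meant among the compounds shown, and "the series" means these compounds.

Compound 1, with the structure `C#CCNC1CCc2c(NCc3ccccc3)cccc21`, is the parent of the first pair. In an assay on cells for inhibition of Amine oxidase [flavin-containing] B (Homo sapiens), read by fluorescence and Amplex Red, with stated times of 30 min and 15 min (on this read-out higher numbers stand for weaker inhibition and lower numbers for stronger inhibition), compound 1 gives only a limit, > 20000 nM. Compound 2, `C#CCNC1CCc2c(NCc3cccc(F)c3)cccc21`, carries the change fluoro in place of hydrogen on an aromatic carbon and in this assay compound 2 gives 1860 nM. The step is an at least 10-fold lower number from compound 1 to compound 2 (1.03 log units; beyond the scatter); it rests on a parent whose value is a limit, (the limit of > 20000 nM in this assay, at which 2 of the 3 values shown sit), so the step itself is known only as a lower bound.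

Compound 3, `C#CCNC1CCc2c(OCCc3cc(NC(=O)c4ccccc4)ccc3Cl)cccc21`, has a different core; the difference between the two cores is not broken down here. In this assay compound 3 gives only a limit, > 20000 nM. Among the measured compounds shown here, compound 4, `C#CCNC1CCc2c(OCCc3cc(NC(=O)c4cccc(F)c4)ccc3Cl)cccc21`, is to be measured in this assay and is made from compound 3 by the change (fluoro in place of hydrogen on an aromatic carbon), which is the same change as the one from compound 1 to compound 2, with the same place in each case, although the core around it differs and the fluorophenyl in compound 4 stands one amide further from the core than in compound 2.

Since compound 3 sits at the limit, the step from compound 3 to compound 4 is estimated to be an at least 2.0-fold lower number from compound 3 to compound 4 (0.30 log units; that floor lies within the scatter), smaller than the measured one and with wide uncertainty. For compound 4 in this assay the expected value is 10000 nM, estimated between 2000 nM and 40000 nM.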

Compound 4, half-maximal inhibitory concentration: > 20000 nM
Compound 4: a limit, no number; the forecaster's own chance of this, stated with the estimate: 45%; at least 2.0-fold (0.30 log units) between middle value and limit.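

In this assay compound 4 gives only a limit, > 20000 nM. Among the compounds shown here, compound 3 also gives only a limit, so no step between compound 3 and compound 4 can be read: the limit of > 20000 nM in this assay, at which 3 of the 4 values shown sit. The compounds shown leave open whether fluoro in place of hydrogen lowers the number at all on the core of compound 3, as it does on the core of compound 1.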